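This account rests on a few compounds, and the source may have more. Where it says the series, first, only, none or still open, it means among the compounds named here.

Measured in a functional assay on thoracic aorta (Rattus norvegicus, strain Wistar), with a stated time of 15 min; on this read-out higher numbers stand for an effect only at larger amounts of compound and lower numbers for an effect already at smaller amounts:
- Compound 1 `CCOc1ccc(F)cc1C(C)NC(=O)NS(=O)(=O)c1ccc(C)cc1`: > 300000 nM
- Compound 2 `CCOc1ccc(Cl)cc1C(C)NC(=O)NS(=O)(=O)c1ccc(C)cc1`: > 300000 nM
- Compound 3 `COc1ccc(OC)c(CNC(=O)NS(=O)(=O)c2ccccc2)c1`: > 300000 nM

The whole set stands at the limit of > 300000 nM in this assay, at which 3 of the 3 values shown sit. For compound 2 the entry > 300000 nM is a limit of the assay and not a number.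

Compound 4 `CCOc1ccc(Cl)cc1C(C)NC(=O)NS(=O)(=O)c1ccccc1` differs from compound 2 by hydrogen in place of methyl on an aromatic carbon, or 4-methylphenyl to phenyl. Within the data shown here, the only measured step, a step that the two limits leave unreadable from compound 1 to compound 2, lies elsewhere and gives no size for this change. Compound 3 also carries phenyl, and its > 300000 nM is likewise a limit.

No step beyond the scatter is therefore expected in this assay, and compound 4 will probably also report only a limit. The estimated change is a number no higher from compound 2 to compound 4 (the limit leaves the size open).

For compound 4 the expected value is 300000 nM, with an estimated range from 100000 nM to 600000 nM.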

Compound 4, half-maximal effective concentration: > 300000 nM
Compound 4 gave a limit, no number (the forecaster's own chance of this, stated with the estimate: 80%); the middle value sits exactly at the limit.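

Compound 2 and compound 4 both give only a limit in this assay, so no step can be read for 4-methylphenyl to phenyl. The compounds shown leave open what any of these structures does at a measurable concentration, and which change would bring a number within reach: the limit of > 300000 nM in this assay, at which 4 of the 4 values shown sit.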